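The compounds below may be only part of what the source reports. "The series", "measured", "known", "first", "only" and "open" are said of these compounds alone.

The study concerns a set of nucleoside derivatives built on a shared core, all measured in an assay on cell membranes (Cricetinae) for displacement of a labelled ligand from adenosine receptor A1 (Homo sapiens); on this read-out higher numbers stand for weaker inhibition and lower numbers for stronger inhibition. Compound 1 `OCc1cnn(-c2nc(Nc3ccc(C(F)(F)F)cc3)c3ncn([C@@H]4O[C@H](CO)[C@@H](O)[C@H]4O)c3n2)c1` gives in this assay 31 nM. Compound 2 `CCOC(=O)c1cnn(-c2nc(NC3CCCCC3)c3ncn([C@@H]4O[C@H](CO)[C@@H](O)[C@H]4O)c3n2)c1` differs from compound 1 in more than one place; in this assay compound 2 gives 30 nM. The two numbers lie within the scatter of each other, so no order can be read between compound 1 and compound 2. Compound 3 `Cc1ccc(Nc2nc(-n3cc(CO)cn3)nc3c2ncn3[C@@H]2O[C@H](CO)[C@@H](O)[C@H]2O)cc1` has not yet been measured in this assay. It differs from compound 1 in one place only: methyl in place of trifluoromethyl on an aromatic carbon. For the measured compounds named here, no pair of measured compounds shows this change on its own, so there is no measured step to lean on; what the change swaps are two groups that carry neither donors nor acceptors and no charge. Compound 3 is expected to land close to compound 1, with a step of a 1.5-fold higher number from compound 1 to compound 3 (0.16 log units; within the scatter) that may well stay within the scatter, leaning if anything toward a somewhat higher number. Compound 3 is estimated at 45 nM, with a range from 12 nM to 160 nM.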

Compound 3, inhibition constant: 74 nM
Beside the measured number, compound 3's estimate is 1.6-fold (0.22 log units) below it; the measured number falls inside the stated range.
By their numbers in this assay, from the lowest: compounds 2 and 1 (each within the scatter of the next); then compound 3.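

In this assay, for the compounds shown here, methyl in place of trifluoromethyl on this aromatic carbon, para to a large group, gives a 2.4-fold higher number from compound 1 to compound 3 (0.38 log units; beyond the scatter), the first step in this set that isolates a single change. It shows that the read-out is not indifferent to which of these two groups sits here, even though neither carries a hydrogen-bond donor, a hydrogen-bond acceptor or a net charge; the step is modest, however, and rests on a single pair. The compounds shown offer no measurement that would explain it.

Going by these compounds, whether the same exchange would give a step of similar size with the rest of the molecule altered, for instance with the ethyl ester of compound 2 in place of the hydroxymethyl group, remains open. Also open, on these data alone, is where other groups on this aromatic carbon, such as a chlorine atom, a methoxy group or an amine, or a bare hydrogen, would fall in this assay relative to trifluoromethyl and methyl.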